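Replacing 4-methoxyphenyl with dimethylcarbamoyl on the chain carbon

The compounds below may be only part of what the source reports. "The series", "measured", "known", "first", "only" and "open" are said of these compounds alone.

Measured in a functional assay on MOLT-4 cells (Homo sapiens) for inhibition, read by MTT assay, with a stated time of 48 h; on this read-out lower numbers stand for stronger inhibition and higher numbers for weaker inhibition:
Compound 1 `CC(C)CCn1cc(/C=C/C(=O)CC(=O)C(=O)O)c2ccccc21`: 20000 nM
Compound 2 `COc1ccc(Cn2cc(/C=C/C(=O)CC(=O)C(=O)O)c3ccccc32)cc1`: > 40000 nM (a limit of the assay)

Compound 2 has no number in this assay, only the limit > 40000 nM. This is the limit of > 40000 nM in this assay, at which 1 of the 2 values shown sits. Compound 3 `CN(C)C(=O)Cn1cc(/C=C/C(=O)CC(=O)C(=O)O)c2ccccc21` has not yet been measured. It carries dimethylcarbamoyl in place of 4-methoxyphenyl on a saturated chain carbon bound to an aromatic nitrogen. Among the measured compounds shown here, the same place was changed in the one measured step that bears on this, an at least 2.0-fold higher number from compound 1 to compound 2 (0.30 log units; that floor lies within the scatter). That step is bounded on one side only, and it involves a different pair of groups, so it gives no firm size or direction for the new change. For the measured compounds named here, the only numeric anchor is compound 1 at 20000 nM. No step beyond the scatter is therefore expected in this assay, and the expected step is an at least 1.1-fold lower number from compound 2 to compound 3 (0.05 log units; that floor lies within the scatter). A result reported only as a limit would also be unsurprising. For compound 3 the estimate is 35000 nM, with an expected range from 15000 nM to 60000 nM.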

Compound 3, half-maximal inhibitory concentration: > 40000 nM
Compound 3 ended at the assay's limit; the forecaster's own chance of this, stated with the estimate: 45%; at least 1.1-fold (0.05 log units) between middle value and limit.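

In this assay, compound 3 gives only a limit of the assay, > 40000 nM, so a second group on the saturated chain carbon bound to an aromatic nitrogen now leaves no measurable number, and this group has no ring, where the 4-methoxyphenyl of compound 2 has a six-membered aromatic ring of carbon only. Dimethylcarbamoyl in place of isobutyl gives an at least 2.0-fold higher number from compound 1 to compound 3 (0.30 log units; that floor lies within the scatter), which does not establish a real loss, while the step from one limit to the other cannot be read. The readings at this position now sit mostly at the ceiling of the assay: the limit of > 40000 nM in this assay, at which 2 of the 3 values shown sit.

Among the compounds shown here, compound 1, at 20000 nM, remains the only true number, so neither the size nor the direction of any effect of these groups can yet be stated. Going by these compounds, how far compound 2 and compound 3 actually lie beyond the limit stays unknown. On these data alone, whether a longer chain, an amine or a carboxylic acid on this chain carbon would give a number that can be compared with compound 1 remains open.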